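The source may report more compounds than this note shows. Statements on the series, on what has been measured and on what is new or still open speak of the compounds shown alone.

Compound 1, `O=C(OCc1ccccc1)N1CCN(C(=S)SCc2cn(Cc3ccccc3F)nn2)CC1`, in a functional assay on ECa-109 cells (Homo sapiens) for inhibition, read by MTT assay, with a stated time of 72 h (on this read-out higher numbers stand for weaker inhibition and lower numbers for stronger inhibition), gives 27000 nM. Compound 2, `S=C(SCc1cn(Cc2ccccc2Cl)nn1)N1CCNCC1`, gives > 128000 nM, which is a limit of this assay. Compound 3, `Fc1ccccc1Cn1cc(CSC(=S)N2CCNCC2)nn1`, gives > 128000 nM, also a limit. Compound 3 thus stands at the limit of > 128000 nM in this assay, at which 2 of the 3 values shown sit, with no number of its own in this assay.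

The change to compound 4, `S=C(SCc1cn(Cc2ccc(Cl)cc2)nn1)N1CCNCC1`, is 4-chlorophenyl in place of 2-fluorophenyl on a saturated chain carbon bound to an aromatic nitrogen. Among the measured compounds shown here, two measured steps touch compound 3: an at least 4.7-fold higher number from compound 1 to compound 3 (0.67 log units; beyond the scatter), which exchanges the group on an amine nitrogen in a ring rather than the halogen, and a step that the two limits leave unreadable from compound 2 to compound 3, the only halogen exchange among the measured compounds, whose size cannot be read. Compound 4 is therefore expected to stay at the limit, with a number no higher from compound 3 to compound 4 (the limit leaves the size open) as the estimated step. The estimate for compound 4 is 128000 nM, from 40000 nM to 300000 nM.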

Compound 4, half-maximal inhibitory concentration: > 128000 nM
Compound 4: only a limit was reported (the forecaster's own chance of this, stated with the estimate: 75%); the middle value sits exactly at the limit.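

Compound 2, compound 3 and compound 4 all sit at a limit, so neither step to compound 4 can be read. The compounds shown leave open whether exchanging the halogen-bearing phenyl group changes anything in this assay.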